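The source may report more compounds than this note shows. Statements on the series, on what has been measured and on what is new or still open speak of the compounds shown alone.

Compound 1 `Cc1ncc([N+](=O)[O-])n1CC(=O)NS(=O)(=O)c1ccc(Cl)cc1`: 0.92 ug/mL
Compound 2 `Cc1ncc([N+](=O)[O-])n1CC(=O)NS(=O)(=O)c1ccccc1`: 2.93 ug/mL
Compound 3 `Cc1ccc(S(=O)(=O)NC(=O)Cc2ccc(F)cc2)cc1`: 9.94 ug/mL

Measured in a functional assay on B16-F10 cells (Mus musculus) for antiproliferative activity, read by MTT assay, with a stated time of 48 h (on this read-out lower numbers stand for stronger inhibition and higher numbers for weaker inhibition), compound 2 stands second highest of the three numbers shown. Its nearest neighbour is compound 1, which gives 0.92 ug/mL, and the furthest is compound 3, which gives 9.94 ug/mL; both gaps lie beyond the scatter.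

Compound 4 `Cc1ccc(S(=O)(=O)NC(=O)Cn2c([N+](=O)[O-])cnc2C)cc1` differs from compound 2 by methyl in place of hydrogen on an aromatic carbon. Among the compounds with values here, the one measured step that touches this place is a 3.2-fold higher number from compound 1 to compound 2 (0.50 log units; beyond the scatter), in which a chloro group on the same aromatic carbon gave way to hydrogen and the number rose by a modest but real amount. Within the data shown here, compound 3 also carries a methyl at such a place, para to a large group, but its other half is built differently, so no single step connects it with compound 4; its value in this assay only shows that a methyl there is compatible with measurable activity. Restoring a substituent where removing chloro cost potency is expected to lower the number for compound 4, though by a smaller step than the chloro removal, and the expected step is a 1.5-fold lower number from compound 2 to compound 4 (0.17 log units; within the scatter). Compound 4 is therefore estimated at 2 ug/mL, with a range from 0.9 ug/mL to 4.5 ug/mL.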

Compound 4, half-maximal inhibitory concentration: 3.55 ug/mL
For compound 4 the middle estimate is 1.8-fold (0.25 log units) below the measured one; the measured number falls inside the stated range.
By their numbers in this assay, from the lowest: compound 1; then compounds 2 and 4 (each within the scatter of the next); then compound 3.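

In this assay, the methyl in place of hydrogen on the six-membered aromatic ring, para to a large group, amounts to a 1.2-fold higher number from compound 2 to compound 4 (0.08 log units; within the scatter), so at this place the two groups cannot be told apart. Chloro does stand apart from methyl, with a 3.9-fold higher number from compound 1 to compound 4 (0.59 log units; beyond the scatter), a step much like a 3.2-fold higher number from compound 1 to compound 2 (0.50 log units; beyond the scatter); among these three compounds, then, the lower number goes with chloro alone, and having a substituent at this place is not enough to bring it. Nothing available explains why chloro differs from methyl and hydrogen here.

The compounds shown leave open whether the lower number of compound 1 is particular to chloro or is shared by groups such as fluoro, bromo, methoxy, trifluoromethyl or an amine at the same place. Going by these compounds, they also test the change from hydrogen to methyl on a single core, so whether it would be equally silent with the different remainder of compound 3 remains open.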